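Isomeric piperidine amides on the nitro sulfone core

The compounds below may be only part of what the source reports. "The series", "measured", "known", "first", "only" and "open" are said of these compounds alone.

Two amides on the shared core, compound 1, `CN(Cc1cccc(F)c1)C(=O)CNC(=O)c1ccc(S(C)(=O)=O)c([N+](=O)[O-])c1`, and compound 2, `CC1CCN(C(=O)CCNC(=O)c2ccc(S(C)(=O)=O)c([N+](=O)[O-])c2)CC1`, have been measured in an assay on isolated protein for inhibition of thyroid hormone receptor alpha (Homo sapiens), read by fluorescence polarization; a higher number here means a weaker inhibitor, a lower number a stronger inhibitor. Compound 1 gives only a limit in this assay, > 60000 nM. Compound 2 likewise gives only a limit in this assay, > 60000 nM. The two values therefore coincide: the limit of > 60000 nM in this assay, at which 2 of the 2 values shown sit. Within the data shown here, no step between measured compounds can be drawn, since neither value is a number.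

Compound 3, `CS(=O)(=O)c1ccc(C(=O)NCCCC(=O)N2CCCCC2)cc1[N+](=O)[O-]`, is the next compound for this assay. Against compound 2 the change is ((piperidin-1-yl)carbonyl)methyl in place of (4-methylpiperidin-1-yl)carbonyl on a saturated chain carbon, two bonds along the chain from an amide-type nitrogen. The two have the same atoms, joined differently, so the change redistributes the chain and the ring rather than adding or removing anything.

Among the measured compounds shown here, with compound 2 standing at the limit and no measured step available, the pair gives no direction to read from. The step from compound 2 to compound 3 is expected to be a step that the limit leaves unreadable from compound 2 to compound 3, that is, none beyond the scatter. Compound 3 is expected to stay at the limit in this assay, estimated at 80000 nM, within 25000 nM to 250000 nM.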

Compound 3, half-maximal inhibitory concentration: > 60000 nM
Compound 3 ended at the assay's limit; the forecaster's own chance of this, stated with the estimate: 85%; the middle value does not contradict the limit.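

Compound 3 gives only a limit in this assay, > 60000 nM. No step can be read between compound 2 and compound 3, and the values shown all coincide: the limit of > 60000 nM in this assay, at which 3 of the 3 values shown sit. The compounds shown leave open whether any amide on the shared core reaches a measurable value in this assay.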